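The compounds below may be only part of what the source reports. "The series", "measured", "known", "first", "only" and "open" are said of these compounds alone.

Measured compounds in an ADME assay on HepG2 cells (Homo sapiens) for cytotoxicity, read by trypan blue exclusion, with a stated time of 48 h, in the presence of a further agent that is not named here; a higher number here means that more compound is tolerated, a lower number that less compound is tolerated:

Compound 1 `c1ccc(Cn2cnc3c(-c4ccco4)nccc32)cc1` gives a limit, > 25000 nM; this is the limit of > 25000 nM in this assay, at which 1 of the 3 values shown sits.
Compound 2 `COc1ccccc1NC(=O)COc1cc(C)nc2ccc(C(F)(F)F)cc12` gives a limit, > 128000 nM; this is the limit of > 128000 nM in this assay, at which 1 of the 3 values shown sits.
Compound 3 `COc1cccc(NC(=O)COc2cc(C)nc3ccc(OC)cc23)c1` gives 43000 nM.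

Within the data shown here, compound 3 stands as the only compound of the three with a number in this assay; the other two results are limits and allow no ordering against it. Among the measured compounds shown here, no two measured compounds differ in one place, so no measured step is available.

Compound 4 `COc1ccc2nc(C)cc(OCC(=O)NCCCc3ccccc3)c2c1` is the next compound for this assay. Relative to compound 3 the change is 3-phenylpropyl in place of 3-methoxyphenyl on an amide-type nitrogen; the aryl substituent on the amide nitrogen is exchanged for a three-carbon chain ending in a phenyl ring, and the methoxy acceptor is lost. For the measured compounds named here, no measured pair in the set shows what such a change does to tolerated concentration, so the step expected, a 1.0-fold higher number from compound 3 to compound 4 (0.02 log units; within the scatter), is set as none beyond the scatter. The estimate for compound 4 is 45000 nM, with a range from 15000 nM to 130000 nM.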

Compound 4, half-maximal cytotoxic concentration: > 137000 nM
Compound 4: no number, only a limit; the forecaster's own chance of this, stated with the estimate: 30%; middle value at least 3.0-fold (0.48 log units) from the limit.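

Among these compounds, the exchange of 3-methoxyphenyl for 3-phenylpropyl on an amide-type nitrogen gives the first measured step in this assay, an at least 3.1-fold higher number from compound 3 to compound 4 (0.50 log units; beyond the scatter). The result for compound 4 is a limit, not a number: the limit of > 137000 nM in this assay, at which 1 of the 4 values shown sits. For this one pair the direction of the change at this nitrogen is therefore fixed, while the step has only a lower end and no upper one.

A single pair does not separate the loss of the methoxy group from the change of aryl to a chain ending in a phenyl ring. From the compounds shown here alone, how an unsubstituted phenyl, or a propyl chain ending in an amine, on the same nitrogen would read in this assay remains open.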